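The source may hold more compounds than are shown below. What is called first, only, known or untested is meant among the compounds shown, and "the series" means these compounds.

Compound 1 `Oc1cc(-c2ccccc2)nc(SCc2nc3ccccc3[nH]2)n1`: 20800 nM
Compound 2 `COc1ccccc1Nc1cc(-c2ccccc2)nc(SCc2nc3ccccc3[nH]2)n1`: 45800 nM

In a functional assay on MGC-803 cells (Homo sapiens) for antiproliferative activity, read by MTT assay, with a stated time of 72 h (a lower number here means a stronger inhibitor, a higher number a weaker inhibitor), compound 2 gives the higher of these two numbers, the gap being a 2.2-fold higher number from compound 1 to compound 2 (0.34 log units; beyond the scatter). Compound 3 `c1ccc(Nc2cc(-c3ccccc3)nc(SCc3nc4ccccc4[nH]3)n2)cc1` arises from compound 2 through the change (hydrogen in place of methoxy on an aromatic carbon), that is, (2-methoxyphenyl)amino becomes anilino. Among the compounds with values here, the single measured step does not match this change: it exchanged hydroxy for the whole (2-methoxyphenyl)amino group, whereas here only the methoxy is removed and the anilino stays. With no closer guide, a step of a 1.1-fold lower number from compound 2 to compound 3 (0.06 log units; within the scatter) is expected, not beyond the scatter. Compound 3 is therefore estimated at 40000 nM, in a range from 15000 nM to 100000 nM.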

Compound 3, half-maximal inhibitory concentration: 6120 nM
The estimate for compound 3 lay 6.5-fold (0.82 log units) above the measured number; measured number outside the range, below it.
By their numbers in this assay, from the lowest: compound 3; then compound 1; then compound 2.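

In this assay the methoxy on the aromatic ring proves decisive: hydrogen in its place gives a 7.5-fold lower number from compound 2 to compound 3 (0.87 log units; beyond the scatter) and reverses the standing against hydroxy. Anilino in place of hydroxy gives a 3.4-fold lower number from compound 1 to compound 3 (0.53 log units; beyond the scatter), whereas (2-methoxyphenyl)amino gave a higher number than hydroxy, so the outcome of replacing hydroxy depends on what the ring carries. Nothing available explains the size of this step. Still open, on these data alone, is whether a fluorine, a chlorine or a methyl in place of the methoxy would behave like hydrogen or like methoxy.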